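Chloro in Place of Hydrogen, Tried on a Second Core

A few compounds are considered here, and "the series" means these few. Any claim that something is new, unique, unknown or untested is made for them only; others in the source may bear on it.

Measured so far, in a functional assay on the whole organism (strain albino) for inhibition, with Rattus norvegicus as the target, read by paw edema, with a stated time of 1 h, at a dose of 100 mg/kg by the oral route; on this read-out higher numbers stand for more inhibition at the one dose given (going by the name of the read-out) and lower numbers for less inhibition:
compound 1, `O=C(CSc1nc(-c2ccccc2)c(C(=O)O)c(=O)[nH]1)Nn1c(COc2ccc(Cl)cc2Cl)nc2ccccc2c1=O`, gives 69.1%
compound 2, `O=C(CSc1nc(-c2ccc(Cl)cc2)c(C(=O)O)c(=O)[nH]1)Nn1c(COc2ccc(Cl)cc2Cl)nc2ccccc2c1=O`, gives 58.2%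
compound 3, `Cn1c(SCC(=O)Nn2c(COc3ccc(Cl)cc3Cl)nc3ccccc3c2=O)nc(-c2ccccc2)c(C#N)c1=O`, gives 54.6%

Compound 1 and compound 2 differ in one place only: chloro in place of hydrogen on an aromatic carbon. This change made the step of a number 10.9 percentage points lower from compound 1 to compound 2 (beyond the scatter). Compound 3 carries a different core; its difference from compound 1 is not broken down here. Compound 4, `Cn1c(SCC(=O)Nn2c(COc3ccc(Cl)cc3Cl)nc3ccccc3c2=O)nc(-c2ccc(Cl)cc2)c(C#N)c1=O`, is compound 3 with the same change applied: chloro in place of hydrogen on an aromatic carbon. Because the step of a number 10.9 percentage points lower from compound 1 to compound 2 (beyond the scatter) went downward on the first core, a step of similar size and direction is expected on the second, so the estimated step is a number 9.6 percentage points lower from compound 3 to compound 4 (within the scatter). Compound 4 is therefore expected to give about 45% in this assay, with a likely range from 32% to 58%.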

Compound 4, a percentage reported as inhibition, in the whole organism at one dose (the size of the read-out at that dose, not a potency): 76.4%
Estimate against measurement, compound 4: 31.4 percentage points below; the whole stated range lies below it.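

In this assay, going from phenyl to 4-chlorophenyl gave a number 21.8 percentage points higher from compound 3 to compound 4 (beyond the scatter), so the step seen on the first core did not carry over to the second: the same change on two cores in this assay, a number 10.9 percentage points lower (beyond the scatter) from compound 1 to compound 2 and a number 21.8 percentage points higher (beyond the scatter) from compound 3 to compound 4, 32.7 percentage points apart, beyond the scatter of two such steps. This shows that, for these two cores, the effect of chloro in place of hydrogen depends on the core that carries it. It does not show which feature of the cores matters, as they differ in more than one place, and two pairs give no rule for a third core.

Open, going by these compounds, is whether fluoro or methoxy in the same place would follow either step. Also open, on these data alone, is what the chloro step would be on a core carrying only one of those differences.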